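Adding a second chloro to a chlorinated purine core

This account rests on a few compounds, and the source may have more. Where it says the series, first, only, none or still open, it means among the compounds named here.

Of the compounds shown here, three have been measured in a functional assay on TK-10 cells (Homo sapiens) for cytotoxicity, read by sulforhodamine B assay, with a stated time of 48 h; a lower number here means that less compound is tolerated, a higher number that more compound is tolerated. Compound 1 `ClCc1ccc(Cn2cnc3c(Cl)ncnc32)cc1` gives 22900 nM. Compound 2 `ClCc1ccccc1Cn1cnc2ncnc(Cl)c21` gives 33900 nM. Compound 3 `ClCc1ccc(Cn2cnc3c(Cl)nc(Cl)nc32)cc1` gives 44700 nM. Compound 3 arises from compound 1 by one change, (chloro in place of hydrogen on an aromatic carbon), and that change gave a step of a 2.0-fold higher number from compound 1 to compound 3 (0.29 log units; within the scatter). Compound 2 has the same atoms as compound 1 joined differently; the difference between the two cores is not broken down here, and their two values lie close together.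

Compound 4 `ClCc1ccccc1Cn1cnc2nc(Cl)nc(Cl)c21` is not yet measured. It arises from compound 2 by chloro in place of hydrogen on an aromatic carbon. The place of this change, on an aromatic carbon of a six-membered aromatic ring with two nitrogen atoms, between two ring nitrogen atoms and meta to a chloro group, matches the place of the change from compound 1 to compound 3 word for word, so it is the same change applied to a second core. For the measured compounds named here, the step from compound 2 to compound 4 is therefore expected to be a 1.6-fold higher number from compound 2 to compound 4 (0.21 log units; within the scatter), resting on the one earlier example, a 2.0-fold higher number from compound 1 to compound 3 (0.29 log units; within the scatter), which stayed within the scatter. Compound 4 is estimated at 55000 nM, most likely between 25000 nM and 120000 nM.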

Compound 4, concentration lethal to 50% of the cells: 60300 nM
The estimate for compound 4 lay 1.1-fold (0.04 log units) below the measured number; low and high end bracket the measured number.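

In this assay, chloro in place of hydrogen on an aromatic carbon gives a 1.8-fold higher number from compound 2 to compound 4 (0.25 log units; within the scatter), and this step can be set beside the one on the other core: the same change on two cores in this assay, a 2.0-fold higher number (0.29 log units; within the scatter) from compound 1 to compound 3 and a 1.8-fold higher number (0.25 log units; within the scatter) from compound 2 to compound 4, 1.1-fold (0.04 log units) apart, within the scatter of two such steps

On these two cores, then, the change reads alike, and the step on the first core was a fair guide to the step on the second. Each step on its own stays within the scatter, however, so neither shows that the chloro alters the result at all, and two pairs make no rule for other cores in the series.

The compounds shown carry only hydrogen or chloro on the carbon between two ring nitrogen atoms, so it stays open whether an amine or a methoxy group there would give a step beyond the scatter. Going by these compounds, it also stays open whether the two steps would still match in a different cell line.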